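The source may hold more compounds than are shown below. What is called first, only, known or untested is meant among the compounds shown, and "the series" means these compounds.

Compound 3 `O=C(/C=C/c1ccc(OCc2cn(Cc3ccccc3Br)nn2)cc1)c1ccc([N+](=O)[O-])cc1` was tested in a functional assay on A549 cells (Homo sapiens) for inhibition, read by MTT assay, with a stated time of 48 h, tested at 10 uM (a higher number here means more inhibition of growth at the concentration tested, a lower number less inhibition of growth), where compound 3 gives 42%. Compound 1 `COc1ccc(C(=O)/C=C/c2ccc(OCc3cn(Cc4ccc(Br)cc4)nn3)cc2)cc1` gives 50% in this assay, a number within the usual scatter of that of compound 3, so the two cannot be told apart. Compound 2 `O=C(/C=C/c1ccc(OCc2cn(Cc3ccccc3)nn2)cc1)c1ccc([N+](=O)[O-])cc1` was reported in this assay only as "not active" (no number reported), with no number. Compound 4 `O=C(/C=C/c1ccc(OCc2cn(Cc3ccc(Br)cc3)nn2)cc1)c1ccc([N+](=O)[O-])cc1` has not yet been measured. It differs from compound 3 in one group: 4-bromophenyl in place of 2-bromophenyl on a saturated chain carbon bound to an aromatic nitrogen. Going by the values given here, no measured pair shows this change by itself, so no step size is known from the data; compound 1, which also carries the 4-bromobenzyl group, gives 50%. Compound 4 is therefore expected to give about 45%, with a range from 25% to 62%. The expected step is a number 3 percentage points higher from compound 3 to compound 4 (within the scatter), which would stay within the scatter.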

Compound 4, percent growth inhibition at one concentration: 18%
For compound 4 the middle estimate is 27 percentage points above the measured one; the whole stated range lies above it.
By their numbers in this assay, from the lowest: compound 4; then compounds 3 and 1 (each within the scatter of the next).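

In this assay, the place of the bromine on the benzyl group matters on its own: 2-bromobenzyl to 4-bromobenzyl gives a number 24 percentage points lower from compound 3 to compound 4 (beyond the scatter), a change beyond the scatter even though no atom is added or lost. With 4-bromobenzyl held fixed, nitro in place of methoxy on an aromatic carbon gives a number 32 percentage points lower from compound 1 to compound 4 (beyond the scatter), so that group counts as well. No measured evidence explains either step.

As far as these compounds go, whether the bromine step holds with methoxy in place of nitro remains open. So does how 3-bromophenyl, or an amine in place of nitro, would behave.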